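The source may report more compounds than this note shows. Statements on the series, on what has been measured and on what is new or still open speak of the compounds shown alone.

Working notes on the series. In a functional assay on PC-3 cells (Homo sapiens) for antiproliferative activity, read by MTT assay, with a stated time of 12 h (on this read-out higher numbers stand for weaker inhibition and lower numbers for stronger inhibition), compound 3 `COc1cc(OC)c2c(=O)cc(/C=C/c3ccc(C(F)(F)F)cc3)oc2c1` gives > 40000 nM, which is a limit of the assay and not a number. Compound 1 `COc1cc(OC)c2c(=O)cc(/C=C/c3ccc(Cl)cc3)oc2c1` gives > 40000 nM in this assay, also a limit. Compound 2 `COc1cc(/C=C/c2cc(=O)c3c(OC)cc(OC)cc3o2)cc(OC)c1` gives > 40000 nM, again a limit. Going by the values given here, the one measured step that changes a single place, a step that the two limits leave unreadable from compound 1 to compound 3, cannot be read, since both of its ends sit at the limit of > 40000 nM in this assay, at which 3 of the 3 values shown sit. Compound 4 `COc1cc(OC)c2c(=O)cc(/C=C/c3ccc(Br)cc3)oc2c1` differs from compound 3 by bromo in place of trifluoromethyl on an aromatic carbon; the bromo enters on an aromatic carbon of a six-membered aromatic ring of carbon only, para to a large group. No readable measured step bears on this exchange, and every value in the set rests at the limit, so no step beyond the scatter in this assay can be foreseen in either direction. Compound 4 is therefore expected to give 60000 nM in this assay, within 20000 nM to 200000 nM, and most probably to return only a limit once more. This estimate means an expected step that the limit leaves unreadable from compound 3 to compound 4.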

Compound 4, half-maximal inhibitory concentration: > 40000 nM
Compound 4 was reported as a limit; the forecaster's own chance of this, stated with the estimate: 85%; the middle value lies beyond the limit too.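

No new step can be read from compound 3 to compound 4 or from compound 1 to compound 4, as compound 4 also returns only a limit: the limit of > 40000 nM in this assay, at which 4 of the 4 values shown sit. The compounds shown leave open whether any change on the shared core would give a measurable value in this assay.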